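The compounds below may be only part of what the source reports. "The series", "measured", "known", "first", "only" and "open" are said of these compounds alone.

Notes on the series. Two members of the shared core have been run in a functional assay on MCF7 cells (Homo sapiens) for antiproliferative activity, read by MTT assay, with a stated time of 72 h; a lower number here means a stronger inhibitor, a higher number a weaker inhibitor. Compound 1 `Cc1cccc(CSc2cc(Cl)c(C)cc2S(=O)(=O)/N=C(\N)N/N=C/C#Cc2ccccc2)c1` gives 16000 nM in this assay. Compound 2 `Cc1cc(S(=O)(=O)/N=C(\N)N/N=C/C#Cc2ccccc2)c(SCc2ccccc2C(F)(F)F)cc1Cl` gives 14000 nM in this assay. For the measured compounds named here, the one step between them, a 1.1-fold lower number from compound 1 to compound 2 (0.06 log units; within the scatter), exchanges the ring held on a saturated chain carbon bound to a sulfur and does not move the number beyond the scatter. Compound 2 holds the lowest of the two numbers, with compound 1 within the scatter of it, so no order between the two can be claimed.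

Compound 3 `Cc1cc(S(=O)(=O)/N=C(\N)N/N=C/C#Cc2ccccc2)c(SCc2ccc(C(F)(F)F)cc2)cc1Cl` is the next member. Its difference from compound 2 is 4-(trifluoromethyl)phenyl in place of 2-(trifluoromethyl)phenyl on a saturated chain carbon bound to a sulfur: the same atoms, joined differently. Going by the values given here, only the step from compound 1 to compound 2 bears on this change, since it too rearranges the ring on that saturated chain carbon, and it reads as flat in this assay. On that ground the change is expected to give no step beyond the scatter in this assay, that is, no change at the digits printed from compound 2 to compound 3 (within the scatter). Compound 3 is therefore estimated at 14000 nM in this assay, with a range from 6000 nM to 35000 nM.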

Compound 3, half-maximal inhibitory concentration: 105000 nM
Compound 3: middle estimate off by 7.5-fold (0.88 log units), on the low side; measured number above the stated range.
By their numbers in this assay, from the lowest: compounds 2 and 1 (each within the scatter of the next); then compound 3.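

For the compounds shown here, the step of a 7.5-fold higher number from compound 2 to compound 3 (0.88 log units; beyond the scatter) shows that in this assay the ring on a saturated chain carbon bound to a sulfur is not a place where every change is flat, as the only earlier step had suggested: moving from 2-(trifluoromethyl)phenyl to 4-(trifluoromethyl)phenyl keeps the same atoms, yet the number rises beyond the scatter. The second step, a 6.6-fold higher number from compound 1 to compound 3 (0.82 log units; beyond the scatter), points the same way and sets compound 3 apart from both earlier compounds, while 3-methylphenyl and 2-(trifluoromethyl)phenyl remain within the scatter of each other. Nothing measured is at hand to account for this difference between the two trifluoromethyl isomers.

The compounds shown leave open whether the higher number goes with the 4-(trifluoromethyl)phenyl group alone or with other rings of this kind, since a plain phenyl, a 4-methylphenyl and a pyridine ring do not appear among them. Also open, as far as these compounds go, is how a longer chain in place of the single saturated chain carbon would read, and whether any change at this place could bring the number below that of compound 2.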